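The source may report more compounds than this note shows. Statements on the series, on what has been measured and on what is new or still open speak of the compounds shown alone.

Compound 3 `FC(F)(F)c1cccc2cc(-c3nn[nH]n3)cnc12` holds the lowest of the two plain numbers measured in a functional assay on the whole organism (strain Sprague-Dawley) for inhibition, with Rattus norvegicus as the target; on this read-out higher numbers stand for an effect only at larger amounts of compound and lower numbers for an effect already at smaller amounts: compound 3 gives 25 mg/kg. Compound 1 `O=C(O)c1cnc2c(Cl)cccc2c1` carries a carboxy group where compound 3 carries the tetrazole and a chloro where compound 3 carries the trifluoromethyl. In this assay compound 1 gives 150 mg/kg. That gap between compound 3 and compound 1 lies beyond the scatter. Compound 2 `Cc1cccc2cc(C(=O)O)cnc12` is known in this assay only as a limit of the assay, > 25 mg/kg. For that reason the step that the limit leaves unreadable from compound 1 to compound 2 cannot be given a size. That limit is the limit of > 25 mg/kg in this assay, at which 1 of the 3 values shown sits.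

Compound 4 `O=C(O)c1cnc2c(C(F)(F)F)cccc2c1` differs from compound 3 in one place: carboxy in place of 2H-tetrazol-5-yl on an aromatic carbon. For the measured compounds named here, no measured step swaps these two groups, so the guide is indirect. Going by the values given here, the one carboxy compound with a plain number, compound 1, gives 150 mg/kg in this assay, well above compound 3. Compound 4 is therefore expected to sit higher than compound 3, an estimated step of a 3.0-fold higher number from compound 3 to compound 4 (0.48 log units; beyond the scatter). For compound 4 the estimate in this assay is 75 mg/kg, expected to fall between 25 mg/kg and 200 mg/kg.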

Compound 4, minimum effective dose: 75 mg/kg
Estimate against measurement, compound 4: no gap at the digits printed; low and high end bracket the measured number.
By their numbers in this assay, from the lowest: compound 3; then compounds 4 and 1 (each within the scatter of the next).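

For the compounds shown here, compound 3 and compound 4 give the first direct comparison of the 2H-tetrazol-5-yl and carboxy groups on an otherwise identical core: in this assay, changing the first group to the second gives a 3.0-fold higher number from compound 3 to compound 4 (0.48 log units; beyond the scatter), so at this place the 2H-tetrazol-5-yl compound acts at the smaller dose. Among the carboxy compounds, trifluoromethyl in place of chloro gives a 2.0-fold lower number from compound 1 to compound 4 (0.30 log units; within the scatter), so this change cannot be told apart from the usual variation between repeated measurements. The steps involving compound 2 cannot be read because its value is only a limit: the limit of > 25 mg/kg in this assay, at which 1 of the 4 values shown sits.

On these data alone, it remains open whether the advantage of the 2H-tetrazol-5-yl group would hold with chloro or methyl in place of trifluoromethyl. As far as these compounds go, it is also open how a different group at this place, such as a nitrile or a primary amide, would compare.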